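A few compounds are considered here, and "the series" means these few. Any claim that something is new, unique, unknown or untested is made for them only; others in the source may bear on it.

Notes on the series in a functional assay on HepG2 cells (Homo sapiens) for antiproliferative activity, with a stated time of 72 h; on this read-out higher numbers stand for an effect only at larger amounts of compound and lower numbers for an effect already at smaller amounts. Compound 1 `C=CCNC(=O)n1c(-c2ccc(OC)cc2)cc(=O)c2c(OC)cc(OC)cc21` returns only the limit > 20000 nM. Compound 2 `COc1ccc(-c2c(I)c(=O)c3c(OC)cc(OC)cc3n2S(=O)(=O)c2ccc(OC)cc2)cc1` likewise gives only the limit > 17300 nM. Compound 3 `COc1cc(OC)c2c(=O)cc(C(=O)Nc3cccc(N4CCCC4)c3)[nH]c2c1` also comes back at the limit > 58600 nM. Among the measured compounds shown here, every value so far is therefore a limit, and compound 3 stands at the limit of > 58600 nM in this assay, at which 1 of the 3 values shown sits, with no measured number anywhere in the set against which a step could be sized. Compound 4 `COc1cc(OC)c2c(=O)cc(C(=O)Nc3cccc(-c4nccs4)c3)[nH]c2c1` differs from compound 3 by 1,3-thiazol-2-yl in place of pyrrolidin-1-yl on an aromatic carbon. For the measured compounds named here, with no measured step available, no direction can be read from the data; the expectation is that compound 4 stays where compound 3 stands, with no step beyond the scatter. The expected step is an at least 1.1-fold lower number from compound 3 to compound 4 (0.06 log units; that floor lies within the scatter). Compound 4 is estimated at 50000 nM, within 15000 nM to 150000 nM, most likely again reported only as a limit.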

Compound 4, half-maximal effective concentration: > 54000 nM
Compound 4: a limit, no number (the forecaster's own chance of this, stated with the estimate: 75%); middle value at least 1.0-fold (0.03 log units) from the limit.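

Compound 3 and compound 4 both return only limits in this assay, so the step between them, 1,3-thiazol-2-yl in place of pyrrolidin-1-yl, cannot be read. The compounds shown leave open at what concentration any of them takes effect.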